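Carbamate for amide on an acylguanidine in mouse

The compounds below may be only part of what the source reports. "The series", "measured", "known", "first", "only" and "open" are said of these compounds alone.

The set holds three measured compounds and one awaiting measurement. Compound 1 (`CC(C)NC(=N)NC1=NC(=O)CN1c1cccc(Cl)c1Cl`) carries an unsubstituted guanidine; in an in vivo ADME assay on the whole organism for metabolic stability, with Mus musculus as the target, read by LC-MS, at a dose of 320 mg/kg by the oral route (on this read-out lower numbers stand for a shorter-lived compound and higher numbers for a longer-lived compound), compound 1 gives 0.225 h. Compound 3 (`CC(C)/N=C(\NC1=NC(=O)CN1C)Nc1ccc(Cl)c(Cl)c1`), on the same core but with the aryl and methyl groups placed differently, gives 0.83 h in this assay. Compound 2 (`CCC(CC)C(=O)/N=C(\NC1=NC(=O)CN1c1cccc(Cl)c1Cl)NC(C)C`) bears a (pentan-3-yl)carbonyl on the guanidine. In this assay compound 2 is reported only as a limit of the assay, > 1 h, so no number is known for it. Compound 2 therefore sits at the limit of > 1 h in this assay, at which 1 of the 3 values shown sits, above the two numbers given for the other compounds.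

Compound 4 (`CC(C)N/C(=N/C(=O)OC(C)(C)C)NC1=NC(=O)CN1c1cccc(Cl)c1Cl`) differs from compound 2 in a single place: tert-butoxy in place of pentan-3-yl on a carbonyl carbon, on a carbonyl carbon whose other neighbour is an amide-type nitrogen. Among the compounds with values here, no measured pair in this set shows the effect of such a swap, so the expectation rests on compound 2 alone. The step from compound 2 to compound 4 is expected to be a number no higher from compound 2 to compound 4 (the limit leaves the size open), with no change beyond the scatter in either direction. Compound 4 is expected to give about 1 h in this assay, within a range from 0.4 h to 2.5 h.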

Compound 4, half-life: > 1 h
Compound 4: no number, only a limit; the forecaster's own chance of this, stated with the estimate: 40%; the middle value sits exactly at the limit.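

Compound 4, like compound 2, is reported only as a limit of the assay in this assay, so no step can be read between the two compounds: the limit of > 1 h in this assay, at which 2 of the 4 values shown sit.

The compounds shown leave open how long either compound lasts, and whether tert-butoxy in place of pentan-3-yl on a carbonyl carbon changes the half-life at all.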